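The compounds below may be only part of what the source reports. "The series", "measured", "known", "first", "only" and "open" are said of these compounds alone.

In a functional assay on PC-3 cells (Homo sapiens) for antiproliferative activity, with a stated time of 48 h (on this read-out lower numbers stand for stronger inhibition and higher numbers for weaker inhibition), compound 1 (`CC(=O)c1ccc(-c2ccc(N3CCCC3)nn2)cc1`) gives > 25000 nM, which is a limit of the assay. Compound 2 (`CCN(CC)c1ccc(-c2ccc(C(C)=O)cc2)nn1`) gives > 25000 nM, also a limit. For the measured compounds named here, the one measured step, a step that the two limits leave unreadable from compound 1 to compound 2, has no readable size, and all the series shows so far is the limit of > 25000 nM in this assay, at which 2 of the 2 values shown sit. Compound 3 (`CCOC(=O)c1ccc(-c2ccc(N(CC)CC)nn2)cc1`) has ethoxy in place of methyl on a carbonyl carbon. Going by the values given here, no measured step covers this change, so no shift beyond the scatter is expected in this assay. The expected step is a step that the limit leaves unreadable from compound 2 to compound 3. The estimate for compound 3 is 30000 nM, with an expected range of 12000 nM to 60000 nM.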

Compound 3, half-maximal inhibitory concentration: 1000 nM
Estimate against measurement, compound 3: 30-fold (1.48 log units) above; the whole stated range lies above it.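

Ethoxy in place of methyl on a carbonyl carbon, with diethylamino unchanged, gives an at least 25-fold lower number from compound 2 to compound 3 (1.39 log units; beyond the scatter), so in this assay this position can carry the series off its limit. The change from acetyl to ethoxycarbonyl is the first step in the series with a readable size, and compound 3 alone has a value that is not a limit: the limit of > 25000 nM in this assay, at which 2 of the 3 values shown sit.

Going by these compounds, what a carboxylic acid, a primary amide or a longer alkoxy chain would give on that carbonyl carbon remains open. Also open, on these data alone, is whether pyrrolidin-1-yl in place of diethylamino would keep the activity of compound 3.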